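The source may hold more compounds than are shown below. What is called first, only, known or untested is meant among the compounds shown, and "the series" means these compounds.

Working notes on the series. In a functional assay on MCF7 cells (Homo sapiens) for inhibition, read by MTT assay, with a stated time of 48 h (on this read-out lower numbers stand for stronger inhibition and higher numbers for weaker inhibition), compound 1 (`c1ccc(-c2nn(-c3ccccc3)c3nccc(-c4cccs4)c23)cc1`) gives 39300 nM, compound 2 (`Cc1ccc(-c2ccnc3c2c(-c2ccccc2)nn3-c2ccccc2)cc1`) gives 5590 nM and compound 3 (`O=C(C=CNc1cc(-c2ccccc2)nn1-c1ccccc1)c1ccccc1`) gives 9650 nM. Compound 2 and compound 3 lie within the usual scatter of each other, so neither ranks ahead. Compound 1 stands clearly apart from compound 2. Within the data shown here, the single measured step is a 7.0-fold lower number from compound 1 to compound 2 (0.85 log units; beyond the scatter), with 4-methylphenyl in place of thiophen-2-yl on an aromatic carbon.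

Compound 4 (`Brc1ccc(-c2ccnc3c2c(-c2ccccc2)nn3-c2ccccc2)cc1`) has not yet been measured and keeps the core of compound 2. The change is bromo in place of methyl on an aromatic carbon, in words bromo in place of methyl on an aromatic carbon, or 4-methylphenyl to 4-bromophenyl.

The measured step bears on this only loosely. There, a 7.0-fold lower number from compound 1 to compound 2 (0.85 log units; beyond the scatter) exchanged a whole ring, whereas here the ring stays and only the group on it changes. Among the measured compounds shown here, no measured pair isolates methyl or bromo, so the direction remains open and the expectation rests on compound 2 at 5590 nM. The estimated step is a 1.1-fold lower number from compound 2 to compound 4 (0.05 log units; within the scatter), so no change beyond the scatter is expected in this assay. Compound 4 is expected at 5000 nM, with an estimated range of 2000 nM to 13000 nM.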

Compound 4, half-maximal inhibitory concentration: 13300 nM
Compound 4: the middle estimate sits 2.7-fold (0.42 log units) below what was measured; the measured number lies above the stated range.
By their numbers in this assay, from the lowest: compounds 2, 3 and 4 (each within the scatter of the next, the first and the last beyond it); then compound 1.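

In this assay, among these compounds, the position on an aromatic carbon of a six-membered aromatic ring of carbon only, para to a large group, proves responsive to a small change: with the ring kept, bromo in place of methyl gives a 2.4-fold higher number from compound 2 to compound 4 (0.38 log units; beyond the scatter) and so moves the number beyond the scatter, which the earlier compounds could not show because their only step exchanged a whole ring. The 4-bromophenyl group still compares favourably with thiophen-2-yl, with a 3.0-fold lower number from compound 1 to compound 4 (0.47 log units; beyond the scatter) alongside a 7.0-fold lower number from compound 1 to compound 2 (0.85 log units; beyond the scatter), so both of these 4-substituted phenyl groups give lower numbers than thiophen-2-yl, although the size of that step depends on the group at this position. Nothing at hand accounts for the difference between methyl and bromo here.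

Among the compounds shown here, with only two groups at this position, no trend can be drawn, and it remains open where chloro, methoxy, an amine or a carboxylic acid would fall relative to methyl and bromo. Also open, as far as these compounds go, is whether the phenyl ring without any such group would sit with compound 2, with compound 4 or apart from both.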